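The source may hold more compounds than are shown below. What is called first, only, known or untested is meant among the compounds shown, and "the series" means these compounds.

Measured so far:

compound 1 `Cc1ccc(-c2nn(-c3ccccc3)cc2C(=O)NOCc2ccccc2)cc1` — in a functional assay on A549 cells (Homo sapiens) for antiproliferative activity, read by MTT assay, with a stated time of 48 h, in the presence of a further agent that is not named here (on this read-out lower numbers stand for stronger inhibition of growth and higher numbers for weaker inhibition of growth), compound 1 gives 1140 nM
compound 2 `Cc1ccc(-c2nn(-c3ccccc3)cc2C(=O)NOCc2ccccc2F)cc1` — compound 2 gives 260 nM
compound 3 `O=C(NOCc1ccccc1)c1cn(-c2ccccc2)nc1-c1ccc(F)cc1` — compound 3 gives 10400 nM

From compound 1 to compound 2 the change is fluoro in place of hydrogen on an aromatic carbon. This change gave a 4.4-fold lower number from compound 1 to compound 2 (0.64 log units; beyond the scatter). From compound 1 to compound 3 the change is fluoro in place of methyl on an aromatic carbon, and that gave a 9.1-fold higher number from compound 1 to compound 3 (0.96 log units; beyond the scatter); compound 3 thus stands highest of the three measured numbers, and its gap to compound 2 is larger still.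

Compound 4 `O=C(NOCc1ccccc1F)c1cn(-c2ccccc2)nc1-c1ccc(F)cc1` is not yet measured. It differs from compound 3 by fluoro in place of hydrogen on an aromatic carbon. The place of the change is described in the same words as for the step from compound 1 to compound 2, so the change is taken to be the same change, made on a different core; the two cores differ as described above between compound 1 and compound 3.

With a single measured instance of the change there is no way to say whether it carries over across cores. The working expectation for compound 4 is that the step resembles the one measured earlier, so that a 4.3-fold lower number from compound 3 to compound 4 (0.64 log units; beyond the scatter) is expected in this assay, because the same change gave a 4.4-fold lower number from compound 1 to compound 2 (0.64 log units; beyond the scatter). The estimate for compound 4 is therefore 2400 nM, with a range from 1000 nM to 6000 nM to allow for the step being smaller or larger on this core.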

Compound 4, concentration for 50% growth inhibition: 17500 nM
Beside the measured number, compound 4's estimate is 7.3-fold (0.86 log units) below it, and the stated range ends below it.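

In this assay the change from benzyloxy to (2-fluorobenzyl)oxy does not carry over from the core of compound 1 to the core of compound 3, where it gives a 1.7-fold higher number from compound 3 to compound 4 (0.23 log units; within the scatter), and the two steps differ: the same change on two cores in this assay, a 4.4-fold lower number (0.64 log units; beyond the scatter) from compound 1 to compound 2 and a 1.7-fold higher number (0.23 log units; within the scatter) from compound 3 to compound 4, 7.4-fold (0.87 log units) apart, beyond the scatter of two such steps. Read the other way round, fluoro in place of methyl gives a 67-fold higher number from compound 2 to compound 4 (1.83 log units; beyond the scatter) when the 2-fluorobenzyl group is present, so the two changes do not add up independently in these four compounds: the same change on two cores in this assay, a 9.1-fold higher number (0.96 log units; beyond the scatter) from compound 1 to compound 3 and a 67-fold higher number (1.83 log units; beyond the scatter) from compound 2 to compound 4, 7.4-fold (0.87 log units) apart, beyond the scatter of two such steps. This shows that the size of the step depends on the core within this set, but it rests on a single set of four compounds in one cell line, and it does not show which feature of the core is responsible or how the change would behave on any further core.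

Left open is whether the dependence is specific to fluoro, or whether chloro or methoxy on the same aromatic carbon would behave the same way on both cores. Also open, on these data alone, is how the benzyl change would behave with a group other than methyl or fluoro in their place, such as an amine, a carboxylic acid or a longer chain.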